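The source may report more compounds than this note shows. Statements on the series, on what has been measured and on what is new or still open speak of the compounds shown alone.

In a functional assay on HCT-8 cells (Homo sapiens) for antiproliferative activity, read by MTT assay, with a stated time of 48 h (on this read-out higher numbers stand for weaker inhibition and lower numbers for stronger inhibition), three amides sharing one core have been measured. Compound 1 `C=C(c1cc(OC)c(OC)c(OC)c1)c1ccc(OC)cc1NC(=O)CO` gives 40 nM, compound 2 `C=C(c1cc(OC)c(OC)c(OC)c1)c1ccc(OC)cc1NC(=O)CN` gives 60 nM and compound 3 `C=C(c1cc(OC)c(OC)c(OC)c1)c1ccc(OC)cc1NC(=O)CNCC` gives 590 nM. Compound 1 thus holds the low end of the series together with compound 2, since the two lie within the scatter of each other, and compound 3 stands well apart from both.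

Compound 4 `C=C(c1cc(OC)c(OC)c(OC)c1)c1ccc(OC)c(O)c1NC(=O)CO` keeps the side chain of compound 1 and alters the aromatic ring instead: hydroxy in place of hydrogen on an aromatic carbon. This is hydroxy in place of hydrogen on an aromatic carbon.

Within the data shown here, no measured step touches that carbon, as all three lie on the side chain. They show only how far a single change in this series can move the number: a 1.5-fold higher number from compound 1 to compound 2 (0.18 log units; within the scatter), then a 9.8-fold higher number from compound 2 to compound 3 (0.99 log units; beyond the scatter), and a 15-fold higher number from compound 1 to compound 3 (1.17 log units; beyond the scatter). The size of the large step therefore gives a wide outer bound, not a prediction, and the data offer no direct guide to direction. The expectation is no step beyond the scatter, with a slight lean towards weaker inhibition.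

For compound 4 the expected step is a 1.8-fold higher number from compound 1 to compound 4 (0.24 log units; within the scatter). The estimated value for compound 4 is 70 nM, with an expected range from 20 nM to 250 nM.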

Compound 4, half-maximal inhibitory concentration: 40 nM
For compound 4 the middle estimate is 1.8-fold (0.24 log units) above the measured one, within the range that was stated.
By their numbers in this assay, from the lowest: compounds 1, 4 and 2 (each within the scatter of the next); then compound 3.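

In this assay, among these compounds, the step reads no change at the digits printed from compound 1 to compound 4 (within the scatter), which gives the first measured reading for a change on the aromatic ring rather than on the side chain. It shows that a hydroxy group can take the place of hydrogen on this aromatic carbon, ortho to a ((hydroxymethyl)carbonyl)amino group and ortho to a methoxy group, without a shift beyond the scatter, whereas one side-chain change alone, the ethylamino replacement, gave a 15-fold higher number from compound 1 to compound 3 (1.17 log units; beyond the scatter). No measurement shown here accounts for why the number holds at this carbon.

The compounds shown give a single substituent at this carbon, so it remains open whether a fluoro group, an amine or a carboxylic acid in the same place would also leave the number within the scatter of compound 1, or would move it as far as the largest side-chain step did. It is also open whether the added hydroxy would behave the same way alongside the amino or ethylamino side chains of compound 2 and compound 3, since it is shown only with the side chain of compound 1.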